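The source may hold more compounds than are shown below. What is called first, only, known or untested is meant among the compounds shown, and "the series" means these compounds.

In a functional assay on MDA-MB-231 cells (Homo sapiens) for antiproliferative activity, read by MTT assay, with a stated time of 24 h (on this read-out higher numbers stand for weaker inhibition and lower numbers for stronger inhibition), the three measured compounds are compared. Compound 1 `Cc1cccc(NNC(=O)c2ccc(NS(=O)(=O)c3cnc(O)nc3O)cc2)c1` gives only a limit of the assay, > 20000 nM, in this assay. Compound 2 `O=C(NNc1ccccc1Cl)c1ccc(NS(=O)(=O)c2cnc(O)nc2O)cc1`, by contrast, gives 4010 nM in this assay. The two differ in a single place, (2-chlorophenyl in place of 3-methylphenyl on an amine nitrogen), and that change produced an at least 4.9-fold lower number from compound 1 to compound 2 (0.69 log units; beyond the scatter).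

Compound 3 `Cc1cccc(NNC(=O)c2ccccc2NS(=O)(=O)c2cnc(O)nc2O)c1` is built on another core, made of the same atoms as compound 1 but joined differently; how the two cores differ is not broken down here. In this assay compound 3 gives only a limit, > 20000 nM. Two of the three measured values therefore sit at the same limit, (the limit of > 20000 nM in this assay, at which 2 of the 3 values shown sit).

Compound 4 `O=C(NNc1ccccc1Cl)c1ccccc1NS(=O)(=O)c1cnc(O)nc1O` carries the same change on the core of compound 3: 2-chlorophenyl in place of 3-methylphenyl on an amine nitrogen. Around the place the change is worded identically in both pairs, so it is the same change, set on a different core.

From the compounds shown here alone, whether the step from compound 3 to compound 4 repeats the earlier one is unknown, since the starting point of compound 3 is a limit and the core is not that of compound 1. An expected step of an at least 2.5-fold lower number from compound 3 to compound 4 (0.39 log units; beyond the scatter) is estimated for this pair, resting on the measured step of an at least 4.9-fold lower number from compound 1 to compound 2 (0.69 log units; beyond the scatter). The value of compound 4 in this assay is expected to lie near 8000 nM, between 2500 nM and 30000 nM.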

Compound 4, half-maximal inhibitory concentration: 18900 nM
Beside the measured number, compound 4's estimate is 2.4-fold (0.37 log units) below it; the measured number falls inside the stated range.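

In this assay compound 3 gives > 20000 nM, which is a limit of the assay and not a number. Setting 2-chlorophenyl in place of 3-methylphenyl on the core of compound 3 therefore reads only as an at least 1.0-fold lower number from compound 3 to compound 4 (0.02 log units; that floor lies within the scatter), so this pair does not establish a lower number on this core, nor does it rule out a larger step. On both cores the 2-chlorophenyl compound gives a number while the 3-methylphenyl compound sits at the limit, but that does not settle whether the change carries over from one core to the other with the same size: the same change on two cores in this assay, an at least 4.9-fold lower number (0.69 log units; beyond the scatter) from compound 1 to compound 2 and an at least 1.0-fold lower number (0.02 log units; that floor lies within the scatter) from compound 3 to compound 4; the limit leaves it open whether they differ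

The compounds shown place only 2-chlorophenyl and 3-methylphenyl on the amine nitrogen, so it remains open how 2-methylphenyl or an unsubstituted phenyl would read there, which would help to separate the effect of the chlorine from that of where the substituent sits. From the compounds shown here alone, it also remains open whether a group bearing an amine or a carboxylic acid at that place would give a measured number on either core, rather than a value at the limit.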